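Chloro scan on the anilide ring: expectation for compound 3

The source may hold more compounds than are shown below. What is called first, only, known or untested is meant among the compounds shown, and "the series" means these compounds.

Measured so far:
compound 1 `O=C(CCCCC(S)CCS)Nc1ccccc1` gives 5.5%
compound 2 `O=C(CCCCC(S)CCS)Nc1cccc(Cl)c1` gives 9.78%

Within the data shown here, in a functional assay on NCI-H460 cells (Homo sapiens) for inhibition, read by MTT assay, with a stated time of 24 h, tested at 0.1 ug/mL (a higher number here means more inhibition of growth at the concentration tested, a lower number less inhibition of growth), compound 1 gives 5.5% and stands within the scatter of compound 2, the only other number. Neither compound can be ranked above the other on these data.

The next compound is compound 3 `O=C(CCCCC(S)CCS)Nc1ccc(Cl)cc1`, which differs from compound 1 as follows: chloro in place of hydrogen on an aromatic carbon. The new chloro sits para to a large group.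

Among the measured compounds shown here, the one measured step that bears on this, also chloro in place of hydrogen on an aromatic carbon but at another place on the ring, is a number 4.3 percentage points higher from compound 1 to compound 2 (within the scatter) and stays small. For the measured compounds named here, no measured compound carries chloro at the place it occupies in compound 3, so this is thin evidence. No step beyond the scatter is therefore expected in this assay in either direction.

The estimated step is a number 2.5 percentage points higher from compound 1 to compound 3 (within the scatter) and nothing more is read into it. For compound 3 the expected value is 8% with an estimated range from 1% to 18% in this assay for now.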

Compound 3, percent growth inhibition at one concentration: "not active" (no number reported)
Nothing numeric was reported for compound 3, and the estimate cannot be compared.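

In this assay, among these compounds, compound 3 is recorded as "not active" with no number, so no step from compound 1 to compound 3 can be read. The compounds shown leave open how far chloro para to a large group shifts growth inhibition on the shared core. No measurement at hand bears on this result.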